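A few compounds are considered here, and "the series" means these few. Any claim that something is new, unique, unknown or untested is made for them only; others in the source may bear on it.

Measured compounds:
Compound 1, `Cc1ccc(-c2nc(CNc3ccc(C(=O)NO)cc3)n(-c3ccccc3)n2)o1`: in an assay on Sf9 cells for inhibition of protein deacetylase HDAC6 (Homo sapiens), read by fluorescence, with a stated time of 40 min, tested at 100 nM (on this read-out higher numbers stand for more inhibition at the one concentration tested (going by the name of the read-out) and lower numbers for less inhibition), compound 1 gives 60.7%.
Compound 2, `O=C(NO)c1ccc(NCc2nc(-c3ccccc3Cl)nn2-c2ccccc2)cc1`: in this assay compound 2 gives 75%.

Compound 2 stands highest of the two numbers measured, with compound 1 nearest and lower by a step that is beyond the scatter. The move to compound 3 `Cc1ccc(-c2nc(CNc3ccc(C(=O)NO)cc3)n(-c3ccccc3)n2)s1` is 5-methylthiophen-2-yl in place of 2-chlorophenyl on an aromatic carbon. Among the measured compounds shown here, only one measured step bears on it: a number 14.3 percentage points higher from compound 1 to compound 2 (beyond the scatter). That step exchanged a five-membered ring with one hetero atom for a 2-chlorophenyl and raised inhibition. Compound 3 goes the other way, taking up 5-methylthiophen-2-yl, a group close to the 5-methylfuran-2-yl of compound 1. A fall of roughly the size of that earlier step, beyond the scatter, is therefore expected in this assay. The step expected is a number 12 percentage points lower from compound 2 to compound 3 (beyond the scatter). Compound 3 is estimated at 63%, with a range from 48% to 78%.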

Compound 3, a percentage reported as inhibition, at one concentration (the size of the read-out at that concentration, not a potency): 79.7%
Compound 3: middle estimate off by 16.7 percentage points, on the low side, and the stated range ends below it.
By their numbers in this assay, from the lowest: compound 1; then compounds 2 and 3 (each within the scatter of the next).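

In this assay, this position on the ring with three nitrogens takes a five-membered aromatic ring as readily as a six-membered one: 5-methylthiophen-2-yl in place of 2-chlorophenyl gives a number 4.7 percentage points higher from compound 2 to compound 3 (within the scatter) and so the two groups cannot be told apart here. The earlier step could be read as a penalty for any five-membered ring with one hetero atom, but 5-methylthiophen-2-yl in place of 5-methylfuran-2-yl gives a number 19 percentage points higher from compound 1 to compound 3 (beyond the scatter) and so the lower number goes with the furan group alone among these compounds. Nothing at hand explains the gap between the furan and the thiophene.

Still open, as far as these compounds go, is what the methyl group contributes, which a plain thiophen-2-yl would test. Also open, from the compounds shown here alone, is how an open chain such as n-butyl or an amine such as morpholine would behave at this position.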